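Amino for chloro on a purine-like core: expected cytotoxicity

A few compounds are considered here, and "the series" means these few. Any claim that something is new, unique, unknown or untested is made for them only; others in the source may bear on it.

The study examines a functional assay on RPMI-8226 cells (Homo sapiens) for cytotoxicity, read by sulforhodamine B assay, with a stated time of 48 h (on this read-out higher numbers stand for lower toxicity in this test and lower numbers for higher toxicity in this test), across a small set of closely related compounds. Compound 1, with structure `ClCc1ccccc1Cn1cnc2c(Cl)nc(Cl)nc21`, has no result in this assay; its entry reads "not determined" (no result reported), so it cannot be placed on the scale by a number of its own. Compound 2 `ClCc1cccc(Cn2cnc3c(Cl)nc(Cl)nc32)c1` reaches only a limit of the assay, > 100000 nM, which is the limit of > 100000 nM in this assay, at which 1 of the 3 values shown sits. Within the data shown here, compound 3 `ClCc1ccccc1Cn1cnc2ncnc(Cl)c21` gives 50100 nM in this assay, the one plain number in the set.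

Compound 4 `Nc1nc(Cl)c2ncn(Cc3ccccc3CCl)c2n1` differs from compound 1 by amino in place of chloro on an aromatic carbon. Among the measured compounds shown here, no pair of measured compounds shows this particular change, so its effect in this assay is not known. The two measured compounds both point to weak cytotoxicity, and the change from compound 1 to compound 4 is expected to leave that picture unchanged, with no step beyond the usual scatter, if anything towards a higher number. Compound 4 is therefore expected to give about 80000 nM in this assay, estimated to lie between 20000 nM and 300000 nM.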

Compound 4, concentration lethal to 50% of the cells: > 100000 nM
Compound 4: a limit, no number; the forecaster's own chance of this, stated with the estimate: 45%; at least 1.2-fold (0.09 log units) between middle value and limit.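

In this assay compound 4 gives > 100000 nM, a limit and not a number. Among these compounds, compound 1 has no number to set against it, so no step from compound 1 to compound 4 can be read. The compounds shown leave open what amino in place of chloro on an aromatic carbon does to cytotoxicity.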